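The compounds below may be only part of what the source reports. "The series", "measured", "known", "first", "only" and "open" are said of these compounds alone.

Compound 1 `COc1cc(N)c(Cl)cc1NC(=O)C1CCN(Cc2ccccc2Cl)CC1` stands in a functional assay on the whole organism for antagonist activity, with Mus musculus as the target (on this read-out lower numbers stand for an effect already at smaller amounts and higher numbers for an effect only at larger amounts of compound), at > 4 mg/kg, which is a limit of the assay rather than a number. Compound 2 `COc1cc(N)c(Cl)cc1NC(=O)C1CCN(Cc2cccc(C#N)c2)CC1` likewise gives only a limit, > 4 mg/kg. Compound 3 `COc1cccc(CN2CCC(C(=O)Nc3cc(Cl)c(N)cc3OC)CC2)c1` also gives only a limit, > 4 mg/kg. All three therefore sit at the limit of > 4 mg/kg in this assay, at which 3 of the 3 values shown sit, so the steps a step that the two limits leave unreadable from compound 1 to compound 2, a step that the two limits leave unreadable from compound 1 to compound 3 and a step that the two limits leave unreadable from compound 2 to compound 3 cannot be sized. Compound 4 `CCCN1CCC(C(=O)Nc2cc(Cl)c(N)cc2OC)CC1` differs from compound 1 by ethyl in place of 2-chlorophenyl on a saturated chain carbon bound to an amine nitrogen in a ring. For the measured compounds named here, none of the measured steps puts ethyl in place of 2-chlorophenyl at this place, and none has a readable size, so no direction beyond the scatter can be expected in this assay. The estimate for compound 4 in this assay is 6 mg/kg, between 3 mg/kg and 25 mg/kg. The expected step that the limit leaves unreadable from compound 1 to compound 4 is close to nothing, with another limit the most likely outcome.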

Compound 4, dose for half-maximal effect: > 10 mg/kg
Compound 4: no number, only a limit; the forecaster's own chance of this, stated with the estimate: 70%; at least 1.6-fold (0.22 log units) between middle value and limit.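

Compound 4, like compound 1, compound 2 and compound 3, gives only a limit in this assay, so none of its steps to them can be read. The compounds shown leave open what dose any of them actually needs for half-maximal effect.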